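A few compounds are considered here, and "the series" means these few. Any claim that something is new, unique, unknown or untested is made for them only; others in the source may bear on it.

Compound 1 `CCc1nc(N)c2nn(-c3ccccc3)cc2n1` gives 90 nM in an assay on CHO cells for displacement of a labelled ligand from adenosine receptor A1 (Homo sapiens), read by scintillation counting; a lower number here means a stronger inhibitor, a higher number a weaker inhibitor.
Compound 2 `Nc1nc(Cc2ccccc2Cl)nc2cn(-c3ccccc3)nc12` gives 155 nM in this assay.
Compound 3 `Nc1nc(/C=C/c2ccccc2)nc2cn(-c3ccccc3)nc12` gives 480 nM in this assay.

Compound 2 has the second highest of the three numbers: its gap to compound 1 lies within the scatter, while the step of a 3.1-fold higher number from compound 2 to compound 3 (0.49 log units; beyond the scatter) lies beyond it. Compound 4 `Nc1nc(CCc2ccc(O)cc2)nc2cn(-c3ccccc3)nc12` is not yet measured. It differs from compound 2 in one place: 4-hydroxybenzyl in place of 2-chlorophenyl on a saturated chain carbon bound to an aromatic carbon. The measured step that bears on this place is a 1.7-fold higher number from compound 1 to compound 2 (0.24 log units; within the scatter), which shows that an earlier swap on the same saturated chain carbon stayed within the scatter. The step of a 3.1-fold higher number from compound 2 to compound 3 (0.49 log units; beyond the scatter) acts on an aromatic carbon and is less telling. A small rise, if any, is expected for compound 4: a 1.6-fold higher number from compound 2 to compound 4 (0.21 log units; within the scatter). Compound 4 is therefore estimated at 250 nM, between 100 nM and 700 nM.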

Compound 4, inhibition constant: 420 nM
Beside the measured number, compound 4's estimate is 1.7-fold (0.23 log units) below it; the range from low to high includes it.
By their numbers in this assay, from the lowest: compounds 1 and 2 (each within the scatter of the next); then compounds 4 and 3 (each within the scatter of the next).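

In this assay, this chain position proves less tolerant than the earlier swap there suggested: 4-hydroxybenzyl in place of 2-chlorophenyl gives a 2.7-fold higher number from compound 2 to compound 4 (0.43 log units; beyond the scatter). Putting 4-hydroxyphenyl in place of hydrogen on a saturated chain carbon, two bonds along the chain from an aromatic carbon, gives a 4.7-fold higher number from compound 1 to compound 4 (0.67 log units; beyond the scatter). No measurement shown explains either rise.

As far as these compounds go, the swap alters the ring's substituent and the group's size together, so which of these matters remains open. From the compounds shown here alone, how an amine on that ring, or a longer chain, would compare also remains open.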